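Swapping the Oxazole Aryl Group: Dimethoxyphenyl to Phenyl

The compounds below may be only part of what the source reports. "The series", "measured", "known", "first", "only" and "open" are said of these compounds alone.

Of the compounds shown here, three built on a shared amide-linked piperazine core have been tested in a functional assay on HL-60 cells (Homo sapiens) for inhibition, read by MTT assay, with a stated time of 72 h; on this read-out lower numbers stand for stronger inhibition and higher numbers for weaker inhibition. Compound 1 `C=C(C)c1ccc(N2CCN(C(=O)c3oc(C)nc3-c3ccccc3)CC2)cc1` gave "not active" (no number reported) in this assay. Compound 2 `Cc1cc(C)cc(N2CCN(C(=O)c3oc(C)nc3-c3ccccc3)CC2)c1`, which carries a 3,5-dimethylphenyl on the piperazine, gave 34.5 nM in this assay. Compound 3 `COc1ccc(-c2nc(C)oc2C(=O)N2CCN(c3cccc(Cl)c3)CC2)cc1OC` gave "not active" (no number reported) in this assay, so there is no single number for compound 3, and it shares that position with one other compound, compound 1, which also has no number.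

The next compound, compound 4 `Cc1nc(-c2ccccc2)c(C(=O)N2CCN(c3cccc(Cl)c3)CC2)o1`, keeps the 3-chlorophenyl piperazine of compound 3 but changes the group on the five-membered ring: phenyl in place of 3,4-dimethoxyphenyl on an aromatic carbon. The phenyl that enters is the same group found in compound 1 and compound 2, one of which has a number and one of which does not.

Compound 3 reports no number. No size can therefore be given for the step from compound 3 to compound 4 in this assay, and no direction is computed. The expectation rests on compound 2 showing 34.5 nM with this same phenyl in place. Compound 4 is therefore estimated at 500 nM, within a wide range from 30 nM to 10000 nM.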

Compound 4, half-maximal inhibitory concentration: 39.2 nM
Estimate against measurement, compound 4: 13-fold (1.11 log units) above; measured number inside the range.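

In this assay compound 3, with 3,4-dimethoxyphenyl on the five-membered ring, gives "not active" (no number reported), while compound 4, with phenyl in that place, gives 39.2 nM as a measured number, so this position can carry phenyl alongside the 3-chlorophenyl piperazine; the size of this step cannot be read, as one side has no number. With phenyl on the five-membered ring, 3-chlorophenyl in place of 3,5-dimethylphenyl on the piperazine gives a 1.1-fold higher number from compound 2 to compound 4 (0.06 log units; within the scatter), so these two groups cannot be told apart on this read-out, although compound 1, which carries the same phenyl, gives "not active" (no number reported) and shows that this phenyl does not ensure a measured number. Nothing given here explains these results.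

The compounds shown leave open whether both methoxy groups of compound 3 matter or only one of them, a question that a phenyl with a single methoxy group would address. They also leave open how this position responds to other groups, such as a pyridine ring or a phenyl bearing an amine.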